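From 4-fluorobenzyl to cyclopropyl on an amide-type nitrogen

The compounds below may be only part of what the source reports. "The series", "measured", "known", "first", "only" and "open" are said of these compounds alone.

In a functional assay on CCRF-CEM cells (Homo sapiens) for inhibition, with a stated time of 72 h (on this read-out lower numbers stand for stronger inhibition and higher numbers for weaker inhibition), compound 1 `CCCCNC(=O)C1(N(Cc2ccccc2)C(=O)[C@H](CC(=O)OC)NC(=O)OC(C)(C)C)CCN(Cc2ccccc2)CC1` gives 28000 nM and compound 2 `COC(=O)C[C@H](NC(=O)OC(C)(C)C)C(=O)N(Cc1ccccc1)C1(C(=O)NC(C)(C)C)CCN(Cc2ccccc2)CC1` gives 24000 nM as its reading. Compound 3 `COC(=O)C[C@H](NC(=O)OC(C)(C)C)C(=O)N(Cc1ccc(F)cc1)C1(C(=O)NCc2ccccc2)CCN(Cc2ccccc2)CC1` gives 16000 nM as its reading, which lies within the usual scatter of both others, so it does not stand apart from them.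

Compound 4 `COC(=O)C[C@H](NC(=O)OC(C)(C)C)C(=O)N(C1CC1)C1(C(=O)NCc2ccccc2)CCN(Cc2ccccc2)CC1` differs from compound 3 in one place, where the change cyclopropyl in place of 4-fluorobenzyl on an amide-type nitrogen puts cyclopropyl in place of 4-fluorobenzyl on an amide-type nitrogen.

For the measured compounds named here, only one measured step bears on this: a 1.2-fold lower number from compound 1 to compound 2 (0.07 log units; within the scatter) is a swap of tert-butyl in place of butyl, and it stays within the scatter. Going by the values given here, that step involves neither group at stake here, and no measured compound carries cyclopropyl, so it offers only weak guidance. The estimated move a 1.4-fold higher number from compound 3 to compound 4 (0.14 log units; within the scatter) is expected to stay within the scatter in this assay and has no firm direction. For compound 4 the expected value is 22000 nM with an estimated range of 9000 nM to 50000 nM in this estimate.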

Compound 4, half-maximal inhibitory concentration: 6700 nM
Estimate against measurement, compound 4: 3.3-fold (0.52 log units) above; measured number below the stated range.
By their numbers in this assay, from the lowest: compound 4; then compounds 3, 2 and 1 (each within the scatter of the next).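

In this assay, the step of a 2.4-fold lower number from compound 3 to compound 4 (0.38 log units; beyond the scatter) is the only one so far that goes beyond the scatter, so the group on this amide-type nitrogen, whose other neighbours are a carbonyl carbon and a saturated ring carbon, can shift the reading, if only modestly. It also shows that 4-fluorobenzyl, with its aromatic ring, is not required here for this level of inhibition: cyclopropyl, with 3 heavy atoms against 8, gives the lower number. Nothing measured here explains the shift.

This single swap both shrinks the group and removes the aromatic ring, so the compounds shown cannot separate those two changes. Going by these compounds, how a methyl or a cyclohexyl group on this nitrogen would read remains open.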